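The source may report more compounds than this note shows. Statements on the series, on what has been measured and on what is new or still open speak of the compounds shown alone.

In a functional assay on A549 cells (Homo sapiens) for antiproliferative activity, read by MTT assay (on this read-out lower numbers stand for stronger inhibition and higher numbers for weaker inhibition), compound 3 `O=C1N=C(N2CCC[C@H]2C(=O)Nc2ccc3ncnc(Nc4cccc(Cl)c4)c3c2)S/C1=C/c1cccc(Br)c1` returns only a limit, > 50000 nM. Compound 1 `O=C1N=C(N2CCC[C@H]2C(=O)Nc2ccc3ncnc(Nc4cccc(Cl)c4)c3c2)S/C1=C/c1cccc(Cl)c1` likewise returns only a limit in this assay, > 50000 nM. Compound 2 `Cc1cccc(/C=C2/SC(N3CCC[C@H]3C(=O)Nc3ccc4ncnc(Nc5cccc(Cl)c5)c4c3)=NC2=O)n1`, by contrast, gives 8500 nM in this assay; two of the three values therefore sit at the limit of > 50000 nM in this assay, at which 2 of the 3 values shown sit. Compound 4 `O=C1N=C(N2CCC[C@H]2C(=O)Nc2ccc3ncnc(Nc4cccc(Cl)c4)c3c2)S/C1=C/c1cccnc1Cl` differs from compound 3 by 2-chloropyridin-3-yl in place of 3-bromophenyl on a double-bonded chain carbon bound to a double-bonded ring carbon. For the measured compounds named here, two measured steps bear on this change, each swapping a carbon-only ring for one with a single hetero atom or back: an at least 5.8-fold lower number from compound 1 to compound 2 (0.76 log units; beyond the scatter) and an at least 5.8-fold higher number from compound 2 to compound 3 (0.76 log units; beyond the scatter), while a step that the two limits leave unreadable from compound 1 to compound 3. As compound 4 again carries a ring with one hetero atom, a lower number is expected, roughly an at least 3.3-fold lower number from compound 3 to compound 4 (0.52 log units; beyond the scatter), though the limit leaves the size uncertain. Compound 4 is thus estimated at 15000 nM, within 4000 nM to 50000 nM.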

Compound 4, half-maximal inhibitory concentration: 10800 nM
Beside the measured number, compound 4's estimate is 1.4-fold (0.14 log units) above it; the range from low to high includes it.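

In this assay the 2-chloropyridin-3-yl group gives a second ring with one hetero atom that reads clear of the limit, with an at least 4.6-fold lower number from compound 3 to compound 4 (0.66 log units; beyond the scatter) and with an at least 4.6-fold lower number from compound 1 to compound 4 (0.66 log units; beyond the scatter) as well. The two pyridine rings do not separate, with a 1.3-fold higher number from compound 2 to compound 4 (0.10 log units; within the scatter) as the step between them. Both carbon-only rings, in compound 1 and compound 3, remain at a limit: the limit of > 50000 nM in this assay, at which 2 of the 4 values shown sit.

Whether the ring nitrogen alone carries this stays open, as every ring shown also bears a halogen or a methyl group. A bare pyridin-3-yl ring or a pyrimidine ring lies outside the compounds shown.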